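Cyclopropyl in place of ethoxy: plasma protein binding

The source may hold more compounds than are shown below. What is called first, only, known or untested is meant among the compounds shown, and "the series" means these compounds.

In an ADME assay on a cell-free system (plasma, Homo sapiens) for protein binding, compound 1 `Cc1cc(Nc2ccc(C(F)(F)F)cc2)n2nc(CCO)nc2n1` gives 67% and compound 2 `CCOc1nc2nc(C)cc(Nc3ccc(C(F)(F)F)cc3)n2n1` gives 92.4%. Compound 2 therefore has the lowest unbound fraction of the two measured compounds. Compound 3 `Cc1cc(Nc2ccc(C(F)(F)F)cc2)n2nc(C3CC3)nc2n1` carries cyclopropyl in place of ethoxy on an aromatic carbon. Among the measured compounds shown here, only one measured step bears on this place, ethoxy in place of 2-hydroxyethyl, and it is a 4.3-fold lower unbound fraction from compound 1 to compound 2 (0.64 log units; beyond the scatter). For the measured compounds named here, no measured compound carries cyclopropyl, so that step is only a loose guide. In this assay, a smaller change than that one is expected, probably within the scatter, and leaning towards a slightly higher unbound fraction. The estimated step is a 1.3-fold higher unbound fraction from compound 2 to compound 3 (0.12 log units; within the scatter). For compound 3 the estimated value is 90%, with an expected range of 82% to 95.5%.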

Compound 3, plasma protein binding in the plasma assay: 92.8%
Compound 3: the middle estimate sits 1.4-fold (0.14 log units) (unbound fraction) above what was measured; measured number inside the range.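

In the plasma assay compound 2 gives 92.4% and compound 3 gives 92.8%; exchanging ethoxy for cyclopropyl on this aromatic carbon, with the loss of the ethoxy oxygen and its hydrogen-bond acceptor, gives a 1.1-fold lower unbound fraction from compound 2 to compound 3 (0.02 log units; within the scatter), so the two groups cannot be told apart on plasma protein binding. The step away from 2-hydroxyethyl is now seen with a second group, as a 4.6-fold lower unbound fraction from compound 1 to compound 3 (0.66 log units; beyond the scatter), so it does not depend on ethoxy alone. In a physicochemical assay for lipophilicity, at pH 7.4 (on this read-out higher numbers stand for higher lipophilicity and lower numbers for lower lipophilicity), compound 2 gives 3.1 and compound 3 gives 3.3; the same exchange gives a number 0.20 log units higher from compound 2 to compound 3 (within the scatter), and no measurement at hand explains either reading.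

Going by these compounds, it remains open whether the step from 2-hydroxyethyl follows its hydroxyl or its chain, which a 2-methoxyethyl group at this position would help to separate. How far binding stays level with an amine, a carboxylic acid or a longer alkyl chain here is also unresolved.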